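The source may hold more compounds than are shown below. What is called first, only, known or untested is meant among the compounds shown, and "the series" means these compounds.

Measured compounds:
compound 1, `CC(C)Oc1cc(-c2cncc(-c3cnn(C4COC4)c3)c2)ccc1C(N)=O`: 200 nM
compound 2, `CC(C)Oc1cc(-c2cncc(-c3cnn(C4CCOC4)c3)c2)ccc1C(N)=O`: 390 nM

Two compounds sharing one core have been run in an assay on HeLa cells for inhibition of MAP kinase-interacting serine/threonine-protein kinase 1/2 (Homo sapiens), read by AlphaScreen, with a stated time of 2 h; a lower number here means a stronger inhibitor, a higher number a weaker inhibitor. Compound 1 gives 200 nM, the lowest of the two numbers shown, and compound 2 gives 390 nM. Going by the values given here, the only step between them is a 2.0-fold higher number from compound 1 to compound 2 (0.29 log units; within the scatter), so the two values tell the same story within the scatter and set no order between the two compounds.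

Compound 3, `CC(C)Oc1cc(-c2cncc(-c3c[nH]nc3C3CC3)c2)ccc1C(N)=O`, has not yet been measured in this assay. It differs from compound 1 in one place: 3-cyclopropyl-1H-pyrazol-4-yl in place of 1-(oxetan-3-yl)-1H-pyrazol-4-yl on an aromatic carbon. Among the compounds with values here, no measured step touches this part of the structure; the step from compound 1 to compound 2 concerns only the group on the aromatic nitrogen and stayed within the scatter. There is therefore no basis in the data for expecting a step in this assay beyond the scatter in either direction, and the estimate for compound 3 is anchored on compound 1 with a wide range. Compound 3 is expected to give 250 nM, between 80 nM and 800 nM, which would mean an expected step of a 1.3-fold higher number from compound 1 to compound 3 (0.10 log units; within the scatter).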

Compound 3, half-maximal inhibitory concentration: 370 nM
Beside the measured number, compound 3's estimate is 1.5-fold (0.17 log units) below it; the range from low to high includes it.
By their numbers in this assay, from the lowest: compounds 1, 3 and 2 (each within the scatter of the next).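

In this assay, the change a 1.9-fold higher number from compound 1 to compound 3 (0.27 log units; within the scatter) is a far larger rewrite of this group than the earlier step, which touched only the group on the aromatic nitrogen. Here the four-membered non-aromatic ring with 1 hetero atom leaves and a three-membered non-aromatic ring of carbon only enters, while the counts go from 0 hydrogen-bond donors and 3 hydrogen-bond acceptors to 1 hydrogen-bond donor and 1 hydrogen-bond acceptor. Even so, the step stays within the scatter, so this place on the six-membered aromatic ring with 1 nitrogen accepts both pyrazolyl groups without a readable difference, and no measurement shown here offers any explanation for that.

The two changes in compound 3, the free ring nitrogen and the cyclopropyl on carbon, arrive together, so the compounds shown cannot say what either does alone. On these data alone, it also remains open whether a group of another kind on the pyrazole, such as a piperidine with its basic amine or a carboxylic acid, would move the number beyond the scatter in either direction.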